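Side-chain indole replaced by phenyl in the triazole series

The source may hold more compounds than are shown below. What is called first, only, known or untested is meant among the compounds shown, and "the series" means these compounds.

Measured compounds:
compound 1 `COc1ccc(Cn2c(CCc3ccccc3)nnc2[C@H](NC(=O)C(C)(C)N)c2c[nH]c3ccccc23)c(OC)c1`: 60 nM
compound 2 `COc1ccc(Cn2c(CCc3ccccc3)nnc2[C@H](NCc2ccccc2)c2c[nH]c3ccccc23)c(OC)c1`: > 1000 nM (a limit)
compound 3 `COc1ccc(Cn2c(CCc3c[nH]c4ccccc34)nnc2[C@H](NC(=O)c2cnccn2)c2c[nH]c3ccccc23)c(OC)c1`: 18.5 nM

In an in vitro assay on LLC-PK1 cells for displacement of a labelled ligand from growth hormone secretagogue receptor type 1 (Homo sapiens) (a lower number here means a stronger inhibitor, a higher number a weaker inhibitor), compound 3 gives the lowest of the two numbers, compound 1 the nearest. Compound 2 reaches only a limit (the limit of > 1000 nM in this assay, at which 1 of the 3 values shown sits). Among the compounds with values here, the one measured step, an at least 16-fold higher number from compound 1 to compound 2 (1.22 log units; beyond the scatter), concerns the amine substituent and does not touch the side chain.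

Compound 4 `COc1ccc(Cn2c(CCc3ccccc3)nnc2[C@H](NC(=O)c2cnccn2)c2c[nH]c3ccccc23)c(OC)c1` differs from compound 3 by phenyl in place of 1H-indol-3-yl on a saturated chain carbon, two bonds along the chain from an aromatic carbon. Within the data shown here, no measured step bears on this change; compounds 1 and 3 differ in both this position and the amide, so their values give no clean reading. A step of modest size, if any, is expected, in either direction, a 1.9-fold higher number from compound 3 to compound 4 (0.28 log units; within the scatter). For compound 4 the estimate is 35 nM, range 12 nM to 110 nM.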

Compound 4, half-maximal inhibitory concentration: 5 nM
Compound 4: middle estimate off by 7.0-fold (0.85 log units), on the high side; measured number below the stated range.
By their numbers in this assay, from the lowest: compound 4; then compound 3; then compound 1. At a limit, above all of these: compound 2.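

In this assay, the side-chain indole is not needed for a low number: phenyl in place of 1H-indol-3-yl gives a 3.7-fold lower number from compound 3 to compound 4 (0.57 log units; beyond the scatter). With the phenethyl chain held, the amine substituent still matters, with pyrazin-2-yl in place of 1-amino-1-methylethyl giving a 12-fold lower number from compound 1 to compound 4 (1.08 log units; beyond the scatter) and (pyrazin-2-yl)carbonyl in place of benzyl giving an at least 200-fold lower number from compound 2 to compound 4 (2.30 log units; beyond the scatter). Compound 2 stands at a limit of the assay, not at a number: the limit of > 1000 nM in this assay, at which 1 of the 4 values shown sits.

No measured property accounts for these steps. As far as these compounds go, whether a longer chain, or a fluorine or an amine on the phenyl, keeps the number this low remains open.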